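A Small Swap Between Two Fluorinated Groups

A few compounds are considered here, and "the series" means these few. Any claim that something is new, unique, unknown or untested is made for them only; others in the source may bear on it.

In a functional assay on MDA-MB-231 cells (Homo sapiens) for inhibition, read by MTT assay, with a stated time of 72 h (on this read-out higher numbers stand for weaker inhibition and lower numbers for stronger inhibition), compound 1 `NS(=O)(=O)c1ccc2c(c1)C(=O)C(=O)N2Cc1cccc(C(F)(F)F)c1` gives 17600 nM as its value and compound 2 `NS(=O)(=O)c1ccc2c(c1)C(=O)C(=O)N2Cc1ccc(SC(F)(F)F)cc1` gives 10800 nM as its value. These numbers lie within the usual scatter of each other, so neither compound ranks ahead. Compound 3 `NS(=O)(=O)c1ccc2c(c1)C(=O)C(=O)N2Cc1ccc(C(F)(F)F)cc1` differs from compound 2 by having trifluoromethyl in place of (trifluoromethyl)sulfanyl on an aromatic carbon. Compound 1 also carries trifluoromethyl and gives 17600 nM in this assay as well, so no step beyond the scatter is expected. The estimated 1.3-fold higher number from compound 2 to compound 3 (0.11 log units; within the scatter) stays small. The expected value for compound 3 is 14000 nM (estimated range 6000 nM to 30000 nM).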

Compound 3, half-maximal inhibitory concentration: 16300 nM
Compound 3: middle estimate off by 1.2-fold (0.07 log units), on the low side; the range from low to high includes it.
By their numbers in this assay, from the lowest: compounds 2, 3 and 1 (each within the scatter of the next).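

Measured directly on one pair, trifluoromethyl in place of (trifluoromethyl)sulfanyl, on an aromatic carbon para to a large group, gives a 1.5-fold higher number from compound 2 to compound 3 (0.18 log units; within the scatter) in this assay and so does not separate the two groups. At this position, then, losing the sulfur leaves the number within normal repeat variation. Nothing available explains this outcome.

Still open, from the compounds shown here alone, is whether a different kind of group at this position, such as an amine or a carboxylic acid, would shift the number beyond the scatter.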